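A few compounds are considered here, and "the series" means these few. Any claim that something is new, unique, unknown or untested is made for them only; others in the source may bear on it.

Measured compounds in a functional assay on KB 3-1 cells (Homo sapiens) for cytotoxicity, read by MTT assay, with a stated time of 68 h, tested at 5 uM; on this read-out higher numbers stand for weaker inhibition and lower numbers for stronger inhibition:
Compound 1 `CC1(C)C(CC[C@@H]2[C@@]3(C)CC[C@@H](O)C(C)(C)O[C@@H]3CC[C@]2(C)O)C(C=O)=CCC2C1CC[C@@]2(C)O`: 5 nM
Compound 2 `CC1(C)C(CC[C@@H]2[C@@]3(C)CC[C@@H](O)C(C)(C)O[C@@H]3CC[C@]2(C)O)C(CO)=CCC2C1CC[C@@]2(C)O`: 5.9 nM
Compound 3 `CC1=CCC2C(CC[C@@]2(C)O)C(C)(C)C1CC[C@@H]1[C@@]2(C)CCC(=O)C(C)(C)O[C@@H]2CC[C@]1(C)O`: 5.2 nM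

Compound 2 gives the highest of these three numbers, yet both its neighbours lie within the scatter of it, so the three compounds cannot be told apart on this assay. Compound 4 `CC1=CCC2C(CC[C@@]2(C)O)C(C)(C)C1CC[C@@H]1[C@@]2(C)CC[C@@H](O)C(C)(C)O[C@@H]2CC[C@]1(C)O` differs from compound 2 by hydrogen in place of hydroxy on a saturated chain carbon bound to a double-bonded ring carbon. Among the compounds with values here, the only measured step touching that group is a 1.2-fold higher number from compound 1 to compound 2 (0.07 log units; within the scatter), which stayed within the scatter; no measured step removes the hydroxy itself, and compound 3 carries a different change, so the data give no direct guide. The step to compound 4 is therefore expected to be a 1.0-fold higher number from compound 2 to compound 4 (0.01 log units; within the scatter), none beyond the scatter. Compound 4 is estimated at 6 nM in this assay, within 2.5 nM to 15 nM.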

Compound 4, half-maximal inhibitory concentration: 5 nM
Compound 4: the middle estimate sits 1.2-fold (0.08 log units) above what was measured; the range from low to high includes it.
By their numbers in this assay, from the lowest: compounds 1, 4, 3 and 2 (each within the scatter of the next).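

In this assay, the hydroxy can be replaced by hydrogen on this saturated chain carbon, giving a 1.2-fold lower number from compound 2 to compound 4 (0.07 log units; within the scatter), so the reading does not depend on that hydroxy. Methyl in place of formyl on the double-bonded ring carbon gives no change at the digits printed from compound 1 to compound 4 (within the scatter), so across formyl, hydroxymethyl and methyl this position shows no measurable preference. No measurement here explains this tolerance. 

On these data alone, whether it extends to a carboxylic acid, an amine or a longer chain at this place remains open. So does whether removing the group's carbon altogether would leave the reading unchanged.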